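Methyl on the Linker Nitrogen: Expecting a Modest Rise

This account rests on a few compounds, and the source may have more. Where it says the series, first, only, none or still open, it means among the compounds named here.

Of the compounds shown here, two have been measured in a functional assay on HCT-116 cells (Homo sapiens) for inhibition, read by MTT assay, with a stated time of 72 h, tested at 20 uM; a higher number here means more inhibition at the concentration tested (going by the name of the read-out), a lower number less inhibition. Compound 1 `CN(c1ccc(Oc2ncnc3sccc23)cc1)c1nccc(N2CCCC2)n1` gives 42.2%, while compound 2 `c1ccc2c(c1)CCN(c1ccnc(Nc3ccc(Oc4ncnc5sccc45)cc3)n1)C2` gives 18.1%, the lower of the two numbers and a gap from compound 1 that lies beyond the usual scatter. Compound 3 `CN(c1ccc(Oc2ncnc3sccc23)cc1)c1nccc(N2CCc3ccccc3C2)n1` has not yet been measured. It differs from compound 2 by methyl in place of hydrogen on a nitrogen on an aromatic ring. Compound 1 also carries a methyl at that nitrogen, yet it differs from compound 2 elsewhere as well, so the two values alone cannot be read apart. A small rise is expected for a number 11.9 percentage points higher from compound 2 to compound 3 (beyond the scatter) in this assay, though it may stay within the scatter. Compound 3 is therefore estimated at 30%, within 10% to 55%.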

Compound 3, a percentage reported as inhibition, at one concentration (the size of the read-out at that concentration, not a potency): 57.7%
Compound 3: the middle estimate sits 27.7 percentage points below what was measured; the measured number lies above the stated range.
By their numbers in this assay, from the lowest: compound 2; then compound 1; then compound 3.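

In this assay, within the data shown here, methyl in place of hydrogen on a nitrogen on an aromatic ring, the only change between the two compounds, gives a large step (a number 39.6 percentage points higher from compound 2 to compound 3 (beyond the scatter)), which compound 1 and compound 2 could not show because they differ in two places. With that methyl present in both compounds, 1,2,3,4-tetrahydroisoquinolin-2-yl in place of pyrrolidin-1-yl on an aromatic carbon gives a modest step (a number 15.5 percentage points higher from compound 1 to compound 3 (beyond the scatter)). No measurement shown here explains either rise.

The compounds shown leave open whether an ethyl group or a longer chain on that nitrogen would raise the number further. They also leave open whether the methyl step would have the same size with pyrrolidin-1-yl in place.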